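This account rests on a few compounds, and the source may have more. Where it says the series, first, only, none or still open, it means among the compounds named here.

Of the compounds shown here, three have been tested so far in a functional assay on K562 cells (Homo sapiens), read by MTT assay, with a stated time of 72 h; on this read-out lower numbers stand for stronger inhibition and higher numbers for weaker inhibition. Compound 2 (`Nc1nc2c(c(-c3ccoc3)cn2[C@@H]2O[C@H](CO)[C@@H](O)[C@H]2O)c(=O)[nH]1`) gives 12500 nM, and compound 3 (`Nc1nc2c(c(-c3ccsc3)cn2[C@@H]2O[C@H](CO)[C@@H](O)[C@H]2O)c(=O)[nH]1`) gives 18300 nM. For the measured compounds named here, compound 3 therefore stands level with compound 2, the only other compound with an exact number. The step between them, a 1.5-fold higher number from compound 2 to compound 3 (0.17 log units; within the scatter), swaps one five-membered aromatic ring for another.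

The next compound, compound 4 (`Nc1nc2c(c(-c3cc4ccccc4o3)cn2[C@@H]2O[C@H](CO)[C@@H](O)[C@H]2O)c(=O)[nH]1`), keeps the core of compound 3 and changes one group: 1-benzofuran-2-yl in place of thiophen-3-yl on an aromatic carbon. In words, 1-benzofuran-2-yl stands in place of thiophen-3-yl on an aromatic carbon. The entering group adds a six-membered aromatic ring of carbon only, a change that the step from compound 2 to compound 3 does not test.

The closest guide is compound 1 (`O=c1[nH]cnc2c1c(-c1cc3ccccc3o1)cn2[C@@H]1O[C@H](CO)[C@@H](O)[C@H]1O`), which carries the same 1-benzofuran-2-yl group on a different core. Compound 1 gives > 20000 nM, which is a limit of the assay and not a number. With that one result and one step within the scatter to go on, no change beyond the scatter is expected, though the expectation leans toward a higher number. The estimated step is a 1.3-fold higher number from compound 3 to compound 4 (0.12 log units; within the scatter). Compound 4 is expected at about 24000 nM, with an estimated range from 10000 nM to 50000 nM.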

Compound 4, half-maximal inhibitory concentration: > 20000 nM
Compound 4: no number, only a limit; the forecaster's own chance of this, stated with the estimate: 55%; the middle value lies beyond the limit too.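

In this assay compound 4 reaches only a limit of the assay, > 20000 nM, and not a number. Read as a floor, the change from thiophen-3-yl to 1-benzofuran-2-yl gives an at least 1.0-fold higher number from compound 3 to compound 4 (0.03 log units; that floor lies within the scatter), and the change from furan-3-yl to the same group gives an at least 1.6-fold higher number from compound 2 to compound 4 (0.20 log units; that floor lies within the scatter); neither floor shows that the added six-membered aromatic ring of carbon only raises the number, but neither step shows any gain in strength. The new point is that 1-benzofuran-2-yl now ends at the limit both with and without the amino group on the core, while the step from compound 1 to compound 4 cannot be read, since both of its ends are limits: the limit of > 20000 nM in this assay, at which 2 of the 4 values shown sit.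

As far as these compounds go, how far compound 4 lies beyond its limit stays open, and so does the true size of its steps from compound 2 and compound 3. Also open, from the compounds shown here alone, is whether a phenyl ring, a methyl group or an aminomethyl group on this aromatic carbon would give a clearly lower number than the five-membered rings of compound 2 and compound 3.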